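Swapping a cyanofuran for a fluorophenyl on a shared core

A few compounds are considered here, and "the series" means these few. Any claim that something is new, unique, unknown or untested is made for them only; others in the source may bear on it.

Compound 1, `N#Cc1ccc(-c2nc(N)c3cc(Cc4ccccc4)sc3n2)o1`: in a functional assay on CHO-K1 cells for antagonist activity at adenosine receptor A1 (Homo sapiens), read by a beta-galactosidase reporter and cAMP accumulation, with stated times of 15 min and 6 h (a higher number here means a weaker inhibitor, a lower number a stronger inhibitor), compound 1 gives 3160 nM.
Compound 2, `N#Cc1cccc(-c2nc(N)c3cc(Cc4ccccc4F)sc3n2)c1`: in this assay compound 2 gives < 16 nM, which is a limit of the assay and not a number.

Going by the values given here, compound 1 carries the only actual number in this assay; the one other value shown is a limit, (the limit of < 16 nM in this assay, at which 1 of the 2 values shown sits). Compound 3, `Nc1nc(-c2cccc(F)c2)nc2sc(Cc3ccccc3)cc12`, has not yet been measured there. It differs from compound 1 by 3-fluorophenyl in place of 5-cyanofuran-2-yl on an aromatic carbon. Compound 2, which also bears a six-membered aromatic ring of carbon only at this carbon, reaches the assay limit of < 16 nM. On that basis compound 3 is expected to be a far stronger inhibitor than compound 1 in this assay, a step of a 110-fold lower number from compound 1 to compound 3 (2.02 log units; beyond the scatter), well beyond the usual scatter. For compound 3 the estimate is 30 nM, with a range from 8 nM to 150 nM.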

Compound 3, inhibition constant: 123 nM
Compound 3: middle estimate off by 4.1-fold (0.61 log units), on the low side; the range from low to high includes it.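

The change from 5-cyanofuran-2-yl to 3-fluorophenyl on this aromatic carbon, between two ring nitrogen atoms, gives a 26-fold lower number from compound 1 to compound 3 (1.41 log units; beyond the scatter) in this assay, so the value in this assay depends strongly on the group at this position, at least for these two groups. Compound 2 gives < 16 nM, which is a limit of the assay and not a number, and it differs from compound 1 in more than one place, so only the new step isolates this position. No measurement shown explains the size of the step.

The compounds shown do not separate the contribution of the ring from that of the nitrile or the fluorine. As far as these compounds go, how a plain phenyl, a 3-methoxyphenyl or a morpholine would behave at this carbon remains open.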